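Swapping Bromo for Methoxy on the Aromatic Ring

The source may hold more compounds than are shown below. What is called first, only, known or untested is meant among the compounds shown, and "the series" means these compounds.

Compound 2 `C=CCNC(=O)/C(C)=C(/C)c1ccc(Br)cc1` and compound 1 `C/C(C(=O)NC1CC1)=C(\C)c1ccc(Br)cc1` share one core and differ only at the amide nitrogen. Among the measured compounds shown here, in a toxicity assay on the whole organism (strain Icem-CET (SPF Caw)) for cytotoxicity, with Mus musculus as the target (on this read-out lower numbers stand for an effect already at smaller amounts and higher numbers for an effect only at larger amounts of compound), compound 2 gives 400 mg/kg, the highest of the two numbers measured so far, and compound 1 gives 300 mg/kg; the step of a 1.3-fold higher number from compound 1 to compound 2 (0.12 log units; within the scatter), allyl in place of cyclopropyl on an amide-type nitrogen, lies within the scatter. Compound 3 `C=CCNC(=O)/C(C)=C(/C)c1ccc(OC)cc1` has not yet been measured. It differs from compound 2 by methoxy in place of bromo on an aromatic carbon, para to a large group. For the measured compounds named here, no measured step touches this part of the molecule: the only known step concerns the amide nitrogen, not the aromatic ring. With nothing pointing in either direction, no step beyond the scatter is expected in this assay. For compound 3 the expected step is no change at the digits printed from compound 2 to compound 3 (within the scatter). Compound 3 is therefore estimated at 400 mg/kg, with a range from 200 mg/kg to 800 mg/kg.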

Compound 3, dose for half-maximal effect: 280 mg/kg
The estimate for compound 3 lay 1.4-fold (0.15 log units) above the measured number; the range from low to high includes it.
By their numbers in this assay, from the lowest: compounds 3, 1 and 2 (each within the scatter of the next).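

Among the compounds shown here, this is the first step that touches the aromatic ring, and it replaces bromo with methoxy, a group with more heavy atoms and a hydrogen-bond acceptor that bromo lacks. In this assay the step is a 1.4-fold lower number from compound 2 to compound 3 (0.15 log units; within the scatter), so at this ring carbon, para to a large group, the two compounds cannot be told apart, and this exchange leaves the read-out as close as the earlier exchange on the amide nitrogen did. No measurement available here bears on why the bromo and methoxy compounds read alike.

From the compounds shown here alone, whether an amine or a carboxylic acid on the same ring carbon would give a step beyond the scatter remains open. Also open, going by these compounds, is whether a longer chain on the amide nitrogen, in place of allyl, would do so.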